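A few compounds are considered here, and "the series" means these few. Any claim that something is new, unique, unknown or untested is made for them only; others in the source may bear on it.

Measured so far:
compound 1 `COc1cccc(S(=O)(=O)c2cnc3cc(F)ccc3c2-c2cccc(F)c2)c1`: 3.36 mL/min
compound 2 `N#Cc1cccc(S(=O)(=O)c2cnc3cc(F)ccc3c2-c2cccc(F)c2)c1`: 0.78 mL/min
compound 3 `Cc1ccc(S(=O)(=O)c2cnc3cc(F)ccc3c2-c2cccc(F)c2)cc1C`: 3.71 mL/min

In an ADME assay on microsomes from liver (Homo sapiens) for metabolic stability, tested at 2.5 uM (a lower number here means slower removal, a higher number faster removal of the compound), compound 3 gives the highest of the three numbers, though a 1.1-fold higher number from compound 1 to compound 3 (0.04 log units; within the scatter) is within the scatter; only a 4.8-fold higher number from compound 2 to compound 3 (0.68 log units; beyond the scatter) is beyond it. Compound 4 `COc1ccc(S(=O)(=O)c2cnc3cc(F)ccc3c2-c2cccc(F)c2)cc1` is not yet measured. Its change from compound 3: 4-methoxyphenyl in place of 3,4-dimethylphenyl on a sulfonyl sulfur. The step that bears on it is a 1.1-fold higher number from compound 1 to compound 3 (0.04 log units; within the scatter), where a methoxyphenyl and the 3,4-dimethylphenyl gave numbers within the scatter of each other. The larger steps of a 4.3-fold lower number from compound 1 to compound 2 (0.63 log units; beyond the scatter) and a 4.8-fold higher number from compound 2 to compound 3 (0.68 log units; beyond the scatter) both involve the cyano compound 2 and say nothing about this change. A step of a 1.1-fold lower number from compound 3 to compound 4 (0.05 log units; within the scatter) is therefore expected, not beyond the scatter. Compound 4 is estimated at 3.3 mL/min, with a range of 1.7 mL/min to 6.5 mL/min.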

Compound 4, intrinsic clearance in a liver preparation (reported as CLH), per the amount of preparation that the assay uses: 2.94 mL/min
For compound 4 the middle estimate is 1.1-fold (0.05 log units) above the measured one, and the stated range covers the measured number.
By their numbers in this assay, from the lowest: compound 2; then compounds 4, 1 and 3 (each within the scatter of the next).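

In this assay, placing the methoxy group as 4-methoxyphenyl on the sulfonyl sulfur leaves the number within the scatter of 3-methoxyphenyl (a 1.1-fold lower number from compound 1 to compound 4 (0.06 log units; within the scatter)). The swap from 3,4-dimethylphenyl is also within the scatter (a 1.3-fold lower number from compound 3 to compound 4 (0.10 log units; within the scatter)). Among the four compounds, only 3-cyanophenyl stands apart, and 4-methoxyphenyl in its place gives a step beyond the scatter (a 3.8-fold higher number from compound 2 to compound 4 (0.58 log units; beyond the scatter)).

No supporting measurement accounts for these steps. From the compounds shown here alone, whether an amine or a carboxylic acid on this aromatic ring would track 3-cyanophenyl or the other three groups remains open.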